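Alpha-bromo acetamide series: methyl on the halogenated carbon

The source may hold more compounds than are shown below. What is called first, only, known or untested is meant among the compounds shown, and "the series" means these compounds.

Measured compounds:
compound 1 `NC(=O)NC(=O)/C=C/c1cccc(NC(=O)CBr)c1` — 1380 nM
compound 2 `COc1cc(NC(=O)NC(=O)c2cccc(NC(=O)CBr)c2)cc(OC)c1OC` — 330 nM

Of the compounds shown here, two have numbers so far in a functional assay on CCRF-CEM cells (Homo sapiens) for antiproliferative activity, read by MTT assay, with a stated time of 72 h; a higher number here means a weaker inhibitor, a lower number a stronger inhibitor. In this assay compound 1 gives 1380 nM and compound 2 gives 330 nM. Compound 2 therefore holds the lower of the two numbers, and its gap to compound 1 is beyond the scatter. For the measured compounds named here, the two differ in more than one place, so what their two values show is only that compound 2 is the stronger of the pair here.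

The next compound is compound 3 `COc1cc(NC(=O)NC(=O)c2cccc(NC(=O)C(C)Br)c2)cc(OC)c1OC`. Against compound 2 the change is methyl in place of hydrogen on a saturated chain carbon bound to a bromine atom and a carbonyl carbon. Going by the values given here, no step of this kind has been measured, so there is no internal precedent for its size or direction. A small step is expected, not clearly beyond the scatter, with a slight lean toward a higher number. For compound 3 the value in this assay is estimated at 500 nM, with a range of 150 nM to 2000 nM. The expected step is a 1.5-fold higher number from compound 2 to compound 3 (0.18 log units; within the scatter).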

Compound 3, half-maximal inhibitory concentration: 1330 nM
Compound 3: the middle estimate sits 2.7-fold (0.42 log units) below what was measured; the measured number falls inside the stated range.
By their numbers in this assay, from the lowest: compound 2; then compounds 3 and 1 (each within the scatter of the next).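

In this assay, for the compounds shown here, methyl in place of hydrogen on a saturated chain carbon bound to a bromine atom and a carbonyl carbon gives a 4.0-fold higher number from compound 2 to compound 3 (0.61 log units; beyond the scatter) and so provides the first reading at this position: the added carbon is not neutral here, and the bromomethyl form holds the lower number of this pair. The step rests on a single pair and shows direction and size only for bromomethyl to 1-bromoethyl on the core of compound 2. Nothing available bears on the origin of this step.

Open, from the compounds shown here alone, is whether an ethyl group or a second methyl on the same carbon would continue this trend, and whether chlorine in place of bromine would alter it. Also open, going by these compounds, is whether the same methyl change would give a similar step on the core of compound 1.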